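The source may report more compounds than this note shows. Statements on the series, on what has been measured and on what is new or still open speak of the compounds shown alone.

Working notes on the sorbic-acid series.

Of the compounds shown here, three carry numbers so far. Compound 1 `C/C=C/C=C/C(=O)Nc1cccc([N+](=O)[O-])c1` in a physicochemical assay for lipophilicity (a lower number here means a more polar compound, a higher number a more lipophilic compound), gives 2.49. Compound 2 `C/C=C/C=C/C(N)=O` in this assay gives 0.6, and compound 3 `C/C=C/C=C/C(=O)OC(C)C` in this assay gives 2.26. Compound 1 holds the highest of the three numbers; its nearest neighbour is compound 3, whose number lies lower by an amount within the scatter, so the two cannot be ordered; the furthest is compound 2, whose number lies lower by an amount beyond the scatter. Among the compounds with values here, no pair among the measured compounds differs in one place only, so no single-change step is available within the measured set.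

The next compound is compound 4 `C/C=C/C=C/C(=O)Nc1ccccc1`, to be measured in this assay. Against compound 1 the change is hydrogen in place of nitro on an aromatic carbon.

Nothing measured here speaks directly to this change. The expectation is that the step from compound 1 to compound 4 is small and upward, a number 0.21 log units higher from compound 1 to compound 4 (within the scatter), of a size that may not clear the scatter. Compound 4 is accordingly estimated at 2.7, with a range from 2.3 to 3.1.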

Compound 4, partition coefficient: 2.53
Estimate against measurement, compound 4: 0.17 log units above; the measured number falls inside the stated range.
By their numbers in this assay, from the lowest: compound 2; then compounds 3, 1 and 4 (each within the scatter of the next).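

In this assay, within the data shown here, the first single-change step reads a number 0.04 log units higher from compound 1 to compound 4 (within the scatter), so hydrogen in place of nitro on this aromatic carbon, meta to a group of 8 heavy atoms, gives a step that cannot be told apart from the scatter. Among these compounds, the departure of nitro, with its 3 heavy atoms and 2 hydrogen-bond acceptors, therefore leaves no readable mark on the number at this one position, a point the earlier compounds could not address, since none of them differed from another in one place only. Nothing at hand accounts for the size of this step.

This single step does not tell whether another group on the same aromatic carbon, such as an amine, a carboxylic acid or a methoxy group, would also stay within the scatter of compound 4. Also open, as far as these compounds go, is whether the same exchange would read the same way on another carbon of the aromatic ring, or in a compound with a longer chain in place of the sorbic-acid chain.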